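Halogen Swap on the Benzyl Ring: Chloro to Bromo

A few compounds are considered here, and "the series" means these few. Any claim that something is new, unique, unknown or untested is made for them only; others in the source may bear on it.

Compound 1: `OC[C@H]1O[C@@H](n2cnc3c(NCc4ccc(F)cc4)ncnc32)[C@H](O)[C@@H]1O` — 2700 nM
Compound 2: `OC[C@H]1O[C@@H](n2cnc3c(NCc4ccc(Cl)cc4)ncnc32)[C@H](O)[C@@H]1O` — 218000 nM

Among the compounds with values here, in a functional assay on K562 cells (Homo sapiens) for antiproliferative activity, with a stated time of 72 h (on this read-out higher numbers stand for weaker inhibition and lower numbers for stronger inhibition), compound 1 gives 2700 nM, and compound 2 gives 218000 nM, the higher of the two numbers measured so far. Within the data shown here, the only step measured, an 81-fold higher number from compound 1 to compound 2 (1.91 log units; beyond the scatter), is large and beyond the scatter. Compound 3, `OC[C@H]1O[C@@H](n2cnc3c(NCc4ccc(Br)cc4)ncnc32)[C@H](O)[C@@H]1O`, is not yet measured and differs from compound 2 by bromo in place of chloro on an aromatic carbon. The step from compound 1 to compound 2 bears on this change only in that it also swaps one halogen for another on the same aromatic carbon; it does not show what a further swap will do. With that single step as guidance, compound 3 is expected to fall near compound 2, and the step of a 1.4-fold higher number from compound 2 to compound 3 (0.14 log units; within the scatter) is estimated to lie within or only modestly beyond the scatter. Compound 3 is therefore estimated at 300000 nM, between 70000 nM and 1300000 nM.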

Compound 3, half-maximal inhibitory concentration: 68200 nM
Estimate against measurement, compound 3: 4.4-fold (0.64 log units) above; the measured number lies below the stated range.
By their numbers in this assay, from the lowest: compound 1; then compound 3; then compound 2.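

In this assay, bromo in place of chloro on this aromatic carbon moves the number back toward that of the fluoro compound (a 3.2-fold lower number from compound 2 to compound 3 (0.50 log units; beyond the scatter)), not further in the direction of the first halogen swap. Bromo does not recover the fluoro result, however (a 25-fold higher number from compound 1 to compound 3 (1.40 log units; beyond the scatter)). Across fluoro, chloro and bromo at this position the numbers therefore do not change in one direction: compound 1 gives the lowest, compound 2 the highest, and compound 3 lies between them. The compounds shown leave open how iodo, or a group of another kind such as an amine or a carboxylic acid, would read on the same aromatic carbon. They also leave open whether this uneven order would hold with the halogen elsewhere on the ring. Nothing available explains the order of the three compounds.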